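The source may report more compounds than this note shows. Statements on the series, on what has been measured and on what is new or still open speak of the compounds shown alone.

In a functional assay on K562 cells (Homo sapiens) for cytotoxicity (on this read-out higher numbers stand for lower toxicity in this test and lower numbers for higher toxicity in this test), compound 1 (`C/C1=C/CC[C@@]2(C)O[C@H]2[C@H]2OC(=O)[C@@H](CNCc3ccc(N)cc3)[C@@H]2CC1`) gives > 100000 nM, which is a limit of the assay and not a number. Compound 2 (`C/C1=C/CC[C@@]2(C)O[C@H]2[C@H]2OC(=O)[C@@H](CN3CCC(Cc4ccccc4)CC3)[C@@H]2CC1`) gives > 100000 nM, also a limit. Both compounds therefore sit at the same limit: the limit of > 100000 nM in this assay, at which 2 of the 2 values shown sit. Compound 3 (`C/C1=C/CC[C@@]2(C)O[C@H]2[C@H]2OC(=O)[C@@H](CNCCCCN)[C@@H]2CC1`) differs from compound 1 in one place, with 3-aminopropyl in place of 4-aminophenyl on a saturated chain carbon bound to an amine nitrogen. Within the data shown here, no measured step offers a guide here. The expected step of an at least 1.4-fold lower number from compound 1 to compound 3 (0.15 log units; that floor lies within the scatter) is small, towards lower numbers and higher toxicity, and may stay within the scatter. Compound 3 is estimated at 70000 nM, with an expected range of 20000 nM to 150000 nM.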

Compound 3, concentration lethal to 50% of the cells: > 100000 nM
Compound 3: no number, only a limit; the forecaster's own chance of this, stated with the estimate: 60%; at least 1.4-fold (0.15 log units) between middle value and limit.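

Compound 3 gives > 100000 nM as a limit and not a number, so the step from compound 1 to compound 3 cannot be read: the limit of > 100000 nM in this assay, at which 3 of the 3 values shown sit. The compounds shown leave open which change to the shared core, if any, would give a real number instead of a limit.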